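This account rests on a few compounds, and the source may have more. Where it says the series, first, only, none or still open, it means among the compounds named here.

Measured so far in an ADME assay on liver for metabolic stability, with Liver microsome (Homo sapiens) as the target, read by LC-MS, using microsomes, with a stated time of 5 h; on this read-out higher numbers stand for fast clearance and lower numbers for slow clearance:
- compound 1 `O[C@H](c1ccccn1)C1(c2ccc(OC(F)(F)F)cc2)CCC1` gives 333 mL/min/kg
- compound 2 `O[C@H](c1ccccn1)[C@]1(c2cccc(C(F)(F)F)c2)C[C@H](O)C1` gives 133 mL/min/kg
- compound 3 `O[C@H](c1ccccn1)[C@]1(c2cccc(OC(F)(F)F)c2)C[C@H](O)C1` gives 150 mL/min/kg

Compound 3 stands second highest of the three numbers; compound 2 is nearest, and compound 1 is furthest, with a gap beyond the scatter. Compound 4 `C[C@]1(O)C[C@](c2cccc(OC(F)(F)F)c2)([C@H](O)c2ccccn2)C1` differs from compound 3 by methyl in place of hydrogen on a saturated ring carbon.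

The only step that pairs two of these compounds is a 1.1-fold higher number from compound 2 to compound 3 (0.05 log units; within the scatter), which concerns a different change and is within the scatter. No measured step bears on methyl in place of hydrogen on a saturated ring carbon, so no direction can be drawn from the numbers shown. The step from compound 3 to compound 4 in this assay is therefore expected to be no change at the digits printed from compound 3 to compound 4 (within the scatter), none beyond the scatter. For compound 4 the expected value is 150 mL/min/kg, with a range from 75 mL/min/kg to 300 mL/min/kg.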

Compound 4, clearance: 117 mL/min/kg
Compound 4: middle estimate off by 1.3-fold (0.11 log units), on the high side; low and high end bracket the measured number.
By their numbers in this assay, from the lowest: compounds 4, 2 and 3 (each within the scatter of the next); then compound 1.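

Methyl in place of hydrogen on a saturated ring carbon of the four-membered ring gives a 1.3-fold lower number from compound 3 to compound 4 (0.11 log units; within the scatter) in this assay. For the compounds shown here, this is the first reading at this position, and the added carbon leaves clearance within the scatter. Nothing at hand accounts for this result.

This single step leaves open what other groups on the same ring carbon, such as an ethyl chain, a methoxy or an amine, would do to clearance. It also leaves open whether methyl would read the same way on the other compounds' cores.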